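A few compounds are considered here, and "the series" means these few. Any claim that something is new, unique, unknown or untested is made for them only; others in the source may bear on it.

Compounds measured in a functional assay on MCF7 cells (Homo sapiens) for inhibition, read by MTT assay; on this read-out higher numbers stand for weaker inhibition and lower numbers for stronger inhibition:
- compound 1 `CCCCCCCCn1cc(/C=C/C(=O)c2ccc(NC(=O)CN3CCN(c4ccccc4)CC3)cc2)nn1`: 31900 nM
- compound 2 `CCCCCCCCn1cc(/C=C/C(=O)c2ccc(NC(=O)CN3CCN(c4ccc([N+](=O)[O-])cc4)CC3)cc2)nn1`: 49100 nM

Compound 2 gives the highest of the two numbers in this assay, and its nearest neighbour is compound 1, a step of a 1.5-fold higher number from compound 1 to compound 2 (0.19 log units; within the scatter) away, which is within the scatter. For the measured compounds named here, that single step, nitro in place of hydrogen on an aromatic carbon, is the only comparison available, and it shows no shift beyond the scatter.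

Compound 3 `CCCCCCCCn1cc(/C=C/C(=O)c2ccc(NC(=O)CN3CCN(c4ccccc4OC)CC3)cc2)nn1` differs from compound 2 by 2-methoxyphenyl in place of 4-nitrophenyl on an amine nitrogen in a ring. Going by the values given here, no measured step covers this exchange, so the step from compound 1 to compound 2 is the only guide, and it suggests that substitution on the aryl ring attached to the piperazine nitrogen has moved this assay little, if at all. The expectation for compound 3 is therefore a step of a 1.3-fold lower number from compound 2 to compound 3 (0.11 log units; within the scatter), within the scatter, in no firm direction. Compound 3 is expected to give about 38000 nM in this assay, with a range from 15000 nM to 95000 nM.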

Compound 3, half-maximal inhibitory concentration: 30000 nM
Compound 3: the middle estimate sits 1.3-fold (0.10 log units) above what was measured, and the stated range covers the measured number.
By their numbers in this assay, from the lowest: compounds 3, 1 and 2 (each within the scatter of the next).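

In this assay, the exchange of 4-nitrophenyl for 2-methoxyphenyl on the amine nitrogen in the ring gives a 1.6-fold lower number from compound 2 to compound 3 (0.21 log units; within the scatter), and the exchange of phenyl for 2-methoxyphenyl on the same nitrogen gives a 1.1-fold lower number from compound 1 to compound 3 (0.03 log units; within the scatter). Where the nitro step alone could be read before, there are now three aryl groups on this nitrogen, phenyl, 4-nitrophenyl and 2-methoxyphenyl, and no step among them leaves the scatter, so neither the added methoxy nor the exchange of one substituted phenyl for the other separates these compounds in this read-out. No supporting measurement is available that could explain this lack of separation.

Going by these compounds, it remains open whether a different group on this nitrogen, such as a benzyl or an acetyl in place of the aryl ring, or an amine or a carboxylic acid on the phenyl ring, would shift the number beyond the scatter. The three compounds also share the octyl chain and the rest of the core, so they say nothing about how a shorter chain or a change elsewhere in the core would read in this assay.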